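Working notes: from compound 2 to compound 3

This account rests on a few compounds, and the source may have more. Where it says the series, first, only, none or still open, it means among the compounds named here.

In a functional assay on B16 cells (Mus musculus) for antiproliferative activity, with a stated time of 72 h (on this read-out higher numbers stand for weaker inhibition and lower numbers for stronger inhibition), compound 1 (`Cc1ccc(CNc2ncnc3c2ncn3[C@@H]2O[C@H](CO)[C@@H](O)[C@H]2O)cc1`) stands at "not determined" (no result reported) and offers no number. Compound 2 (`OC[C@H]1O[C@@H](n2cnc3c(NCc4ccc(F)c(F)c4F)ncnc32)[C@H](O)[C@@H]1O`) gives > 166000 nM as its entry, which is a limit and not a number. The change 3-chloro-4-fluorophenyl in place of 2,3,4-trifluorophenyl on a saturated chain carbon bound to a nitrogen on an aromatic ring leads from compound 2 to compound 3 (`OC[C@H]1O[C@@H](n2cnc3c(NCc4ccc(F)c(Cl)c4)ncnc32)[C@H](O)[C@@H]1O`). Within the data shown here, no measured step sizes this change, and no shift beyond the scatter is expected in this assay in either direction. The expected result is an at least 1.1-fold lower number from compound 2 to compound 3 (0.04 log units; that floor lies within the scatter) as the estimated step. For compound 3 the estimate is 150000 nM with an expected range from 50000 nM to 400000 nM in this read-out.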

Compound 3, half-maximal inhibitory concentration: 167000 nM
For compound 3 the middle estimate is 1.1-fold (0.05 log units) below the measured one; low and high end bracket the measured number.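

No step from compound 2 to compound 3 can be read, since compound 2 has a limit and not a number: the limit of > 166000 nM in this assay, at which 1 of the 3 values shown sits.

The compounds shown leave open how 3-chloro-4-fluorophenyl and 2,3,4-trifluorophenyl compare in this assay.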